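Aryl ketone variation at the carbonyl carbon of the series

The compounds below may be only part of what the source reports. "The series", "measured", "known", "first", "only" and "open" are said of these compounds alone.

Two compounds of the series have numbers in a functional assay on SK-BR-3 cells (Homo sapiens) for antiproliferative activity, read by XTT assay, with a stated time of 72 h; a lower number here means a stronger inhibitor, a higher number a weaker inhibitor. Compound 1 `COc1ccc(-c2cc3ccccc3nc2/C=C/C(=O)c2ccc(O)cc2)cc1` gives 3880 nM in this assay. Within the data shown here, compound 2 `COc1ccc(-c2cc3ccccc3nc2/C=C/C(=O)c2ccco2)cc1` gives 640 nM in this assay, the lowest of the two numbers, with compound 1 as its only neighbour; the step of a 6.1-fold lower number from compound 1 to compound 2 (0.78 log units; beyond the scatter) is beyond the scatter and counts as modest. Compound 3 `COc1ccc(-c2cc3ccccc3nc2/C=C/C(=O)c2c[nH]c3ccccc23)cc1` has not yet been measured. The change from compound 2 to compound 3 is 1H-indol-3-yl in place of furan-2-yl on a carbonyl carbon. Among the measured compounds shown here, the only measured step, a 6.1-fold lower number from compound 1 to compound 2 (0.78 log units; beyond the scatter), concerns the same carbonyl carbon but a different exchange, so it bears on the place only, not on the direction of the present change: it shows that the group on the carbonyl carbon can move the number in this assay by a modest amount. For the measured compounds named here, no measured compound carries a 1H-indol-3-yl group, so the direction of the step is open. The expectation for compound 3 is therefore a step of a 1.6-fold higher number from compound 2 to compound 3 (0.19 log units; within the scatter) set near no change, with a range wide enough to cover a modest move either way. Compound 3 is expected to give 1000 nM in this assay, between 250 nM and 4000 nM.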

Compound 3, half-maximal inhibitory concentration: 3450 nM
For compound 3 the middle estimate is 3.5-fold (0.54 log units) below the measured one; the range from low to high includes it.
By their numbers in this assay, from the lowest: compound 2; then compounds 3 and 1 (each within the scatter of the next).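

In this assay, among these compounds, the exchange of furan-2-yl for 1H-indol-3-yl on the carbonyl carbon gives a 5.4-fold higher number from compound 2 to compound 3 (0.73 log units; beyond the scatter), so the first step that starts from the furan-2-yl group also goes against it, and the size of this step matches that of the only earlier step at this carbon. The comparison of the two larger groups gives a 1.1-fold lower number from compound 1 to compound 3 (0.05 log units; within the scatter), which places 4-hydroxyphenyl and 1H-indol-3-yl level within the scatter, while compound 2 alone stands apart, with steps beyond the scatter to both other compounds. No measured information on these compounds accounts for the separation of the furan-2-yl compound from the other two.

The step from furan-2-yl to 1H-indol-3-yl changes several things at once, adding a six-membered aromatic ring of carbon only, a hydrogen-bond donor and more heavy atoms, and the three compounds shown cannot separate these changes. On these data alone, whether the lower number belongs to furan-2-yl in particular or to five-membered aromatic rings more widely stays open, and a thiophen-2-yl group or an unsubstituted phenyl group on the carbonyl carbon would bear directly on that question.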